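The source may hold more compounds than are shown below. What is called first, only, known or untested is meant among the compounds shown, and "the series" means these compounds.

Measured in a functional assay on MDA-MB-231 cells (Homo sapiens) for inhibition, read by MTT assay, with a stated time of 48 h; a higher number here means a weaker inhibitor, a lower number a stronger inhibitor:
- Compound 1 `COc1cc(-c2cc(-c3ccc(Br)cc3)nc(-c3ccccc3)n2)cc(OC)c1OC` gives > 25000 nM (a limit of the assay, not a number)
- Compound 2 `COc1cc(-c2cc(-c3ccc(C)cc3)nc(-c3ccccc3)n2)cc(OC)c1OC` gives 5110 nM (a measured number)

Among the compounds with values here, compound 2 therefore holds the only actual number so far, and it sits on the stronger side of the limit reached by compound 1. The next compound is compound 3 `COc1cc(-c2cc(-c3cccc(O)c3)nc(-c3ccccc3)n2)cc(OC)c1OC`, in which 3-hydroxyphenyl takes the place of 4-methylphenyl on an aromatic carbon (3-hydroxyphenyl in place of 4-methylphenyl on an aromatic carbon). Within the data shown here, one measured step bears on this change, as it altered the same ring: methyl in place of bromo gave an at least 4.8-fold lower number from compound 1 to compound 2 (0.68 log units; beyond the scatter) and so was beyond the scatter. That shows this ring can matter, but it involves no hydroxyl group and gives no clear direction. The expected change is modest and not clearly beyond the scatter, leaning slightly toward a lower number (a 1.5-fold lower number from compound 2 to compound 3 (0.16 log units; within the scatter)). Compound 3 is estimated at 3500 nM (expected range 1000 nM to 15000 nM).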

Compound 3, half-maximal inhibitory concentration: 1990 nM
The estimate for compound 3 lay 1.8-fold (0.25 log units) above the measured number; measured number inside the range.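

In this assay, the aryl group at this position of the shared core can carry a hydroxyl group and still give a stronger inhibitor: 3-hydroxyphenyl in place of 4-methylphenyl gives a 2.6-fold lower number from compound 2 to compound 3 (0.41 log units; beyond the scatter). This step changes both the group and where it sits on the ring, as the names 3-hydroxyphenyl and 4-methylphenyl show, and it does not separate these two changes. With 3-hydroxyphenyl in place of 4-bromophenyl, the result is an at least 12-fold lower number from compound 1 to compound 3 (1.09 log units; beyond the scatter), a size that is only a minimum, as the value for compound 1 is a limit: the limit of > 25000 nM in this assay, at which 1 of the 3 values shown sits.

Going by these compounds, how a hydroxyl group and a methyl group compare when held at the same place on this ring remains open. So does whether an amine or a carboxylic acid there would lower the number further.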